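The source may hold more compounds than are shown below. What is called first, only, known or untested is meant among the compounds shown, and "the series" means these compounds.

Compound 1, `CN1C(=O)C(CCO)COC12C=CC(=O)C=C2`, carries the shared core with a hydroxyethyl side chain and nothing else. In an assay on isolated protein for inhibition of N-lysine methyltransferase SMYD2 (Homo sapiens), read by filter binding, with a stated time of 1 h (on this read-out lower numbers stand for stronger inhibition and higher numbers for weaker inhibition), compound 1 gives > 30000 nM, a value that is a limit of the assay rather than a number. Compound 2, `CN1C(=O)C(CCNc2cc(C(F)(F)F)cc(C(F)(F)F)c2)COC12C=CC(=O)C=C2`, replaces that terminal hydroxyl with an aniline bearing two trifluoromethyl groups, and in this assay compound 2 gives 2130 nM. For the measured compounds named here, that is the only number among the values shown, the other entry being a limit at which one of the two values sits (the limit of > 30000 nM in this assay, at which 1 of the 2 values shown sits).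

Compound 3, `CN1C(=O)C(CCNc2cc(F)cc(C(F)(F)F)c2)COC12C=CC(=O)C=C2`, differs from compound 2 in one place: fluoro in place of trifluoromethyl on an aromatic carbon. Going by the values given here, no measured step of this kind is available. Compound 1, which lacks the whole aryl group, reaches only the limit of this assay. Given that compound 2 sits at 2130 nM, a modest weakening is expected, though one close to the usual scatter. The expected step from compound 2 to compound 3 in this assay is a 2.1-fold higher number from compound 2 to compound 3 (0.32 log units; beyond the scatter). Compound 3 is estimated to give 4500 nM, within a range from 1500 nM to 14000 nM.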

Compound 3, half-maximal inhibitory concentration: 7520 nM
Compound 3: the middle estimate sits 1.7-fold (0.22 log units) below what was measured, and the stated range covers the measured number.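

For the compounds shown here, the replacement of trifluoromethyl by fluoro gives the first measured step on the aryl group in this assay, a 3.5-fold higher number from compound 2 to compound 3 (0.55 log units; beyond the scatter), which shows that this position responds to the group it carries. With fluoro meta to a trifluoromethyl group that stays in place, compound 3 still gives a measurable 7520 nM, so a number in this assay does not depend on the aryl group holding two trifluoromethyl groups. Of the compounds shown, only compound 1 stays at a limit, which is not a number: the limit of > 30000 nM in this assay, at which 1 of the 3 values shown sits.

A single replacement at this position cannot tell why the number rises, and the compounds shown leave open whether hydrogen, chloro, methyl or a nitrile there would fall nearer to compound 2 or to compound 3. Also open, on these data alone, is how the number would respond to a change elsewhere in the side chain, such as a longer chain between the shared core and the aniline nitrogen, or an amide in place of the aniline amine.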